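A few compounds are considered here, and "the series" means these few. Any claim that something is new, unique, unknown or untested is made for them only; others in the source may bear on it.

Compound 1, with structure `CCC[C@]1(C(=O)N2CC[C@](c3ccc(C(F)(C(F)(F)F)C(F)(F)F)cc3)(S(=O)(=O)c3ccc(F)cc3)C2)CC[C@H](C(=O)O)CC1`, has no result in an ADME assay on microsomes from liver (Homo sapiens) for metabolic stability, with a stated time of 10 min; on this read-out higher numbers stand for a more stable compound and lower numbers for a less stable compound: its value stands as "not determined" (no result reported). Its close relative compound 2, with structure `C[C@]1(C(=O)N2CC[C@](c3ccc(C(F)(C(F)(F)F)C(F)(F)F)cc3)(S(=O)(=O)c3ccc(F)cc3)C2)CC[C@@H](C(=O)O)CC1`, gives 85% in this assay. Compound 3, with structure `O=C(N1CC[C@](c2ccc(C(F)(C(F)(F)F)C(F)(F)F)cc2)(S(=O)(=O)c2ccc(F)cc2)C1)C1(CO)CCS(=O)(=O)CC1`, differs from compound 1 by 4-(hydroxymethyl)-1,1-dioxothian-4-yl in place of 4-carboxy-1-propylcyclohexyl on a carbonyl carbon. Since compound 1 has no number, the step from compound 1 to compound 3 cannot be measured; a small fall in this assay is expected, but one that may still lie within the scatter. Resting on compound 2 and its 85%, compound 3 is estimated at 75%, between 50% and 95%.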

Compound 3, percent of the compound remaining: 75%
Compound 3: middle estimate and measured number agree at the digits printed; the measured number falls inside the stated range.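

In this assay, placing 4-(hydroxymethyl)-1,1-dioxothian-4-yl on the carbonyl carbon in place of 4-carboxy-1-methylcyclohexyl gives a number 10 percentage points lower from compound 2 to compound 3 (within the scatter), so at this position a ring with a sulfur atom and no carboxylic acid reads much like the carbon-only ring. Nothing available explains this result.

The step from compound 1 cannot be read. Also open, going by these compounds, is whether an amine in place of the hydroxymethyl on the new ring would give a similar reading in this assay, with the rest of compound 3 unchanged.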